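Swapping 3-bromophenyl for 4-methylphenyl: an expected modest step

A few compounds are considered here, and "the series" means these few. Any claim that something is new, unique, unknown or untested is made for them only; others in the source may bear on it.

Measured so far in a functional assay on HeLa cells (Homo sapiens) for antiproliferative activity, read by sulforhodamine B assay, with a stated time of 72 h; a higher number here means a weaker inhibitor, a lower number a stronger inhibitor:
- compound 1 `N#Cc1ccc(NC(=S)N/N=C/c2ccc3ccccc3n2)cc1`: 20000 nM
- compound 2 `S=C(N/N=C/c1ccc2ccccc2n1)Nc1cccc(Br)c1`: 70000 nM

For the measured compounds named here, of these two, compound 2 has the higher number and is therefore the weaker inhibitor, while compound 1 is its only and nearest neighbour. Compound 3 `Cc1ccc(NC(=S)N/N=C/c2ccc3ccccc3n2)cc1` keeps the shared core, and its change is 4-methylphenyl in place of 3-bromophenyl on an amide-type nitrogen.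

Going by the values given here, only one measured step bears on this change. It is a 3.5-fold higher number from compound 1 to compound 2 (0.54 log units; beyond the scatter), a modest move beyond the scatter, and it came from 3-bromophenyl replacing 4-cyanophenyl at that same place. Among the compounds with values here, no measured compound carries 4-methylphenyl, so the direction remains uncertain. With compound 2 at 70000 nM as the higher of just two values, a modest move towards a lower number is expected in this assay. The expected size is a 2.0-fold lower number from compound 2 to compound 3 (0.30 log units; within the scatter). For compound 3 the estimated value is 35000 nM. The expected range for compound 3 runs from 10000 nM to 100000 nM.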

Compound 3, half-maximal inhibitory concentration: 86000 nM
The estimate for compound 3 lay 2.5-fold (0.39 log units) below the measured number; measured number inside the range.
By their numbers in this assay, from the lowest: compound 1; then compounds 2 and 3 (each within the scatter of the next).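

In this assay, placing 4-methylphenyl instead of 3-bromophenyl on the amide-type nitrogen gave a 1.2-fold higher number from compound 2 to compound 3 (0.09 log units; within the scatter), so this change separates the two compounds by no more than the scatter. The pair that differs at the aromatic carbon tells a different story, with methyl in place of cyano giving a 4.3-fold higher number from compound 1 to compound 3 (0.63 log units; beyond the scatter), a step beyond the scatter. Compound 1, with its 4-cyanophenyl, now stands apart from both compound 2 and compound 3 as the strongest inhibitor of the three, and the 3-bromophenyl and 4-methylphenyl groups cannot be told apart at this position in this assay, although this rests on three compounds only and none of them goes against it.

As far as these compounds go, it remains open whether the lower number belongs to the cyano group in particular, or whether an amine, a carboxylic acid or a methoxy group on that aromatic carbon would give a similar number or a lower one. Nothing available here accounts for why compound 1 separates from the other two.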